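Moving the Methyl Around the Ring in this Series

A few compounds are considered here, and "the series" means these few. Any claim that something is new, unique, unknown or untested is made for them only; others in the source may bear on it.

Compound 1 `Fc1ccc(-c2csc(N/N=C/c3ccccc3)n2)cc1` and compound 2 `Cc1ccccc1/C=N/Nc1nc(-c2ccc(F)cc2)cs1` share one core and differ only by a methyl group on an aromatic carbon. In an in vitro assay on BTI-TN-5B1-4 cells for inhibition of Amine oxidase [flavin-containing] A (Homo sapiens), read by fluorescence, with a stated time of 15 min, tested at 100 uM (a lower number here means less inhibition, a higher number more inhibition at the concentration tested (going by the name of the read-out)), compound 1 gives 40%, and compound 2 gives 40%. The step of no change at the digits printed from compound 1 to compound 2 (within the scatter) shows that adding the methyl left the read-out level within the scatter, so compound 2 stands level with compound 1 on the numbers at hand.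

Compound 3 `Cc1ccc(/C=N/Nc2nc(-c3ccc(F)cc3)cs2)cc1` has the same atoms as compound 2, joined differently: 4-methylphenyl in place of 2-methylphenyl on a carbon with a double bond to nitrogen. For the measured compounds named here, no measured step shifts a methyl from one place to another on this ring, and the single known step, no change at the digits printed from compound 1 to compound 2 (within the scatter), is flat. With compound 2 standing at 40%, nothing in hand points to a move in either direction.

Compound 3 is therefore expected to give 40%, between 25% and 55%, the expected step of no change at the digits printed from compound 2 to compound 3 (within the scatter) staying within the scatter.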

Compound 3, a percentage reported as inhibition, at one concentration (the size of the read-out at that concentration, not a potency): "not active" (no number reported)
The entry for compound 3 holds no number; there is nothing to compare the estimate with.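

For the compounds shown here, compound 3 is recorded as "not active" with no number in this assay, so no step from compound 2 to compound 3 can be read, and no evidence at hand bears on this result. These compounds leave open how far 4-methylphenyl in place of 2-methylphenyl shifts the read-out.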